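The source may hold more compounds than are shown below. What is called first, only, known or untested is meant among the compounds shown, and "the series" means these compounds.

Of the compounds shown here, three have been measured in a functional assay on ileum for inhibition of histamine H1 receptor (Cavia porcellus); a lower number here means a stronger inhibitor, a higher number a weaker inhibitor. Compound 1 `CN1CCN(c2nc3ccccc3n2CCOc2ccccc2)CC1` gives 6.9 nM. Compound 2 `CCCOCCn1c(N2CCN(C)CC2)nc2ccccc21` gives 20 nM; it differs from compound 1 by propyl in place of phenyl on an oxygen on a saturated carbon, and that change made a step of a 2.9-fold higher number from compound 1 to compound 2 (0.46 log units; beyond the scatter). Compound 3 `CN1CCCN(c2nc3ccccc3n2CCOc2ccccc2)CC1` gives 9.1 nM; the two cores differ in that compound 3 carries 4-methyl-1,4-diazepan-1-yl in place of 4-methylpiperazin-1-yl on an aromatic carbon, a change that made a step of a 1.3-fold higher number from compound 1 to compound 3 (0.12 log units; within the scatter). Compound 3 therefore stands close to compound 1, while compound 2 sits at a higher number than either.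

Compound 4 `CCCOCCn1c(N2CCCN(C)CC2)nc2ccccc21` has not yet been measured in this assay. It differs from compound 3 by propyl in place of phenyl on an oxygen on a saturated carbon. This is the same change that separates compound 2 from compound 1, made at the same place on the other core. Because the step from compound 1 to compound 2 was a 2.9-fold higher number from compound 1 to compound 2 (0.46 log units; beyond the scatter), and because compound 3 starts from 9.1 nM, a step of similar size is expected for compound 4, estimated as a 2.9-fold higher number from compound 3 to compound 4 (0.46 log units; beyond the scatter). On that basis compound 4 is expected to give about 26 nM, with a range from 12 nM to 55 nM.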

Compound 4, half-maximal inhibitory concentration: 16 nM
Beside the measured number, compound 4's estimate is 1.6-fold (0.21 log units) above it; the range from low to high includes it.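

In this assay, putting propyl in place of phenyl on the oxygen of compound 3 made a step of a 1.8-fold higher number from compound 3 to compound 4 (0.25 log units; within the scatter). Set beside the same change on the core of compound 1, the two steps cannot be told apart: the same change on two cores in this assay, a 2.9-fold higher number (0.46 log units; beyond the scatter) from compound 1 to compound 2 and a 1.8-fold higher number (0.25 log units; within the scatter) from compound 3 to compound 4, 1.6-fold (0.22 log units) apart, within the scatter of two such steps This shows that the change carried from one core to the other without a detectable difference in its size, but the second step alone lies within the scatter, and two pairs neither fix a size for the change nor show that it would hold on any further core.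

The compounds shown leave open how other groups on that oxygen would read in this assay, for example a butyl chain, a benzyl group or a phenyl ring carrying fluorine. They also leave open whether the step would stay the same with another amine on the aromatic carbon, such as 4-ethylpiperazin-1-yl or a piperidine.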